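Ester isoxazoles on Vero cells: a halogen swap

This account rests on a few compounds, and the source may have more. Where it says the series, first, only, none or still open, it means among the compounds named here.

Measured compounds:
compound 1, `CCOC(=O)c1cc(-c2cccc(OCc3cccc(Cl)c3)c2)on1`: > 128000 nM
compound 2, `CCOC(=O)c1cc(-c2cccc(OCc3ccc(F)cc3)c2)on1`: "not determined" (no result reported)
compound 3, `CCOC(=O)c1cc(-c2cccc(OCc3ccc(Cl)c(Cl)c3)c2)on1`: "not determined" (no result reported)

In an ADME assay on Vero cells (Chlorocebus sabaeus) for cytotoxicity, with a stated time of 72 h (on this read-out higher numbers stand for weaker inhibition and lower numbers for stronger inhibition), compound 1 gives > 128000 nM, which is a limit of this assay and not a number. Compound 2 has no result in this assay, with "not determined" (no result reported) reported. Compound 3, `CCOC(=O)c1cc(-c2cccc(OCc3ccc(Cl)c(Cl)c3)c2)on1`, likewise stands without a single number in this assay, recorded as "not determined" (no result reported); of the three entries shown, one sits at the limit of > 128000 nM in this assay, at which 1 of the 3 values shown sits, and the other is also without a number. Going by the values given here, no step between two measured compounds can therefore be drawn.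

Compound 4, `CCOC(=O)c1cc(-c2cccc(OCc3cc(F)ccc3F)c2)on1`, differs from compound 3 by 2,5-difluorophenyl in place of 3,4-dichlorophenyl on a saturated chain carbon bound to an oxygen on an aromatic ring. Among the compounds with values here, since no measured step connects any two compounds here, no size or direction of change in this assay can be read from the data, and the expectation for compound 4 rests only on the single limit seen for compound 1. Compound 4 is expected to give about 150000 nM in this assay, within a range from 40000 nM to 400000 nM, most likely reported again as a limit rather than a number.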

Compound 4, half-maximal inhibitory concentration: > 128000 nM
Compound 4: no number, only a limit; the forecaster's own chance of this, stated with the estimate: 70%; the middle value lies beyond the limit too.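

Going by these compounds alone, no step from compound 1 to compound 4 can be read, since both entries are limits and not numbers in this assay: the limit of > 128000 nM in this assay, at which 2 of the 4 values shown sit.

From the compounds shown here alone, whether any of these halogen swaps shifts the result in this assay, and where compound 2 and compound 3 stand, remains open.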